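A few compounds are considered here, and "the series" means these few. Any claim that something is new, unique, unknown or untested is made for them only; others in the source may bear on it.

Measured in a functional assay on MX1 cells (Homo sapiens) for inhibition, read by MTT assay, with a stated time of 120 h; on this read-out higher numbers stand for weaker inhibition and lower numbers for stronger inhibition:
- compound 1 `O=C(/C=C/c1ccc(NC(=O)Nc2ccc(Cl)c(C(F)(F)F)c2)cc1)NC1CCC1`: 4530 nM
- compound 2 `CNC(=O)/C=C/c1ccc(NC(=O)Nc2ccc(Cl)c(C(F)(F)F)c2)cc1`: 13800 nM
- compound 3 `O=C(CCc1ccc(NC(=O)Nc2ccc(Cl)c(C(F)(F)F)c2)cc1)NC1CCC1`: 24000 nM

The open question is compound 4 `CNC(=O)CCc1ccc(NC(=O)Nc2ccc(Cl)c(C(F)(F)F)c2)cc1`, which has not yet been measured. Compound 3 stands clearly apart from compound 1, as shown by a 5.3-fold higher number from compound 1 to compound 3 (0.72 log units; beyond the scatter). Compound 3 and compound 2 cannot be told apart, as a 1.7-fold higher number from compound 2 to compound 3 (0.24 log units; within the scatter) shows. Compound 4 derives from compound 3 through one change, methyl in place of cyclobutyl on an amide-type nitrogen.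

The same exchange has been measured once, in a 3.0-fold higher number from compound 1 to compound 2 (0.48 log units; beyond the scatter), a modest step that goes beyond the scatter. Going by the values given here, that step was taken with the 2-(cyclobutylcarbamoyl)ethenyl compound, so its transfer to the 2-(cyclobutylcarbamoyl)ethyl compound is untested, and no measured pair shows the exchange there. The measured step still offers the best guide, so a modest move towards weaker inhibition is expected, perhaps somewhat smaller than the one seen before. The expected step is a 2.3-fold higher number from compound 3 to compound 4 (0.36 log units; beyond the scatter). The estimated value for compound 4 is 55000 nM, within an expected range of 22000 nM to 130000 nM.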

Compound 4, half-maximal inhibitory concentration: 20400 nM
Beside the measured number, compound 4's estimate is 2.7-fold (0.43 log units) above it; measured number outside the range, below it.
By their numbers in this assay, from the lowest: compound 1; then compounds 2, 4 and 3 (each within the scatter of the next).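

In this assay, the exchange of cyclobutyl for methyl on an amide-type nitrogen leaves no readable difference on the 2-(cyclobutylcarbamoyl)ethyl compound, with a 1.2-fold lower number from compound 3 to compound 4 (0.07 log units; within the scatter), so the step seen with the ethenyl compounds does not carry over to the ethyl compounds: the same change on two cores in this assay, a 3.0-fold higher number (0.48 log units; beyond the scatter) from compound 1 to compound 2 and a 1.2-fold lower number (0.07 log units; within the scatter) from compound 3 to compound 4, 3.6-fold (0.55 log units) apart, beyond the scatter of two such steps

With methyl on that nitrogen, the exchange of ethenyl for ethyl also stays within the scatter, with a 1.5-fold higher number from compound 2 to compound 4 (0.17 log units; within the scatter), while compound 1 remains clearly apart, as shown by a 4.5-fold higher number from compound 1 to compound 4 (0.65 log units; beyond the scatter). Among these four compounds, then, only compound 1, the one that carries cyclobutyl together with the ethenyl link, stands out as the strongest inhibitor, and compounds 2, 3 and 4 cannot be told apart.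

From the compounds shown here alone, only methyl and cyclobutyl appear on this nitrogen, so it stays open whether a cyclopentyl or a phenyl group there would give compound 1's advantage on the ethenyl link, and whether either would make any difference on the ethyl link. Going by these compounds, it also stays open whether a longer chain, such as a propyl link between the amide and the shared core, would behave like the ethyl link or the ethenyl link.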